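The source may hold more compounds than are shown below. What is called first, only, known or untested is meant among the compounds shown, and "the series" means these compounds.

Of the compounds shown here, two have numbers so far. Compound 1 `CC(C)(N)C(=O)N[C@H](COCc1ccccc1)c1nnnn1CCCCCNS(C)(=O)=O` carries a 5-(methanesulfonamido)pentyl chain on the shared core; in a functional assay on H4 cells for agonist activity at growth hormone secretagogue receptor type 1 (Homo sapiens), read by FLIPR (a lower number here means that less compound is needed, a higher number that more compound is needed for the effect), compound 1 gives 75 nM. Compound 2 `COC(=O)C(c1ccccc1)n1nnc([C@@H](COCc2ccccc2)NC(=O)C(C)(C)N)n1` differs in more than one place and is not tied to compound 1 by a single step; in this assay compound 2 gives 3170 nM. Compound 1 therefore holds the lowest of the two numbers, and the gap to compound 2 lies beyond the usual scatter.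

The next candidate, compound 3 `CCCCNC(=O)CCCn1nnnc1[C@@H](COCc1ccccc1)NC(=O)C(C)(C)N`, keeps the core of compound 1 and changes the chain end: butylcarbamoyl in place of 2-(methanesulfonamido)ethyl on a saturated chain carbon, three bonds along the chain from an aromatic nitrogen. Chain length is preserved, one hydrogen-bond donor is kept and one acceptor is lost. Going by the values given here, no measured pair reports this kind of exchange, so its effect is an open question.

Given that the closest neighbour compound 1 gives 75 nM, a modest step is expected from compound 1 to compound 3, a 2.0-fold higher number from compound 1 to compound 3 (0.30 log units; within the scatter), most likely toward a somewhat higher number. For compound 3 in this assay the expected value is 150 nM, with a range from 40 nM to 600 nM.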

Compound 3, half-maximal effective concentration: 30 nM
The estimate for compound 3 lay 5.0-fold (0.70 log units) above the measured number; the measured number lies below the stated range.
By their numbers in this assay, from the lowest: compound 3; then compound 1; then compound 2.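

At this place, on a saturated chain carbon, three bonds along the chain from an aromatic nitrogen, the only single-place exchange shown so far reads in this assay as a 2.5-fold lower number from compound 1 to compound 3 (0.40 log units; beyond the scatter), with butylcarbamoyl in place of 2-(methanesulfonamido)ethyl. For this pair, then, the methanesulfonamido end of the chain is not needed to keep agonist activity: a group of the same heavy-atom count, without sulfur and with a butyl end, gives a lower number, and the step lies beyond the usual scatter. No measurement at hand accounts for this step, and the exchange cannot be assigned to any one part of the group.

The one step changes the linking unit and the chain end together, so the compounds shown leave open whether the lower number goes with the carbonyl-bearing butylcarbamoyl unit as a whole or with the butyl end alone. Also open, going by these compounds, is how this position would respond to a terminal carboxylic acid, a primary amide, an amine or a longer alkyl chain on the carbamoyl nitrogen.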